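The source may hold more compounds than are shown below. What is called first, only, known or untested is meant among the compounds shown, and "the series" means these compounds.

The three measured compounds share one core and differ only in the chain on the amide. Compound 1 `C/C=C/C(=O)Nc1cccc(Oc2nc(Nc3ccn(C)n3)nc3c2CSCC3)c1` carries the shortest chain, and in a functional assay on MCF7 cells (Homo sapiens) for antiproliferative activity, read by MTT assay, with a stated time of 72 h (a higher number here means a weaker inhibitor, a lower number a stronger inhibitor), compound 1 gives 40000 nM. Compound 2 `CCC/C=C/C(=O)Nc1cccc(Oc2nc(Nc3ccn(C)n3)nc3c2CSCC3)c1` gives 22600 nM in this assay. Compound 3 `CC(C)/C=C/C(=O)Nc1cccc(Oc2nc(Nc3ccn(C)n3)nc3c2CSCC3)c1` reaches only a limit of the assay, giving > 50000 nM in this assay, so no number is known for it (the limit of > 50000 nM in this assay, at which 1 of the 3 values shown sits). Among the values shown, compound 2 holds the lowest of the two numbers, its nearest neighbour being compound 1, and the step of a 1.8-fold lower number from compound 1 to compound 2 (0.25 log units; within the scatter) stays within the scatter. The step of an at least 2.2-fold higher number from compound 2 to compound 3 (0.34 log units; beyond the scatter) and the step of an at least 1.2-fold higher number from compound 1 to compound 3 (0.09 log units; that floor lies within the scatter) concern the same chain.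

Compound 4 `CCC/C=C/C(=O)Nc1cccc(Oc2nc(Nc3cccc(C#N)c3)nc3c2CSCC3)c1` leaves that chain as in compound 2 and changes the other end: 3-cyanophenyl in place of 1-methyl-1H-pyrazol-3-yl on a nitrogen on an aromatic ring. None of the three measured steps touches this position; each of them alters only the group on the double-bonded chain carbon, so the measurements give no direct guide to the size or direction of this change. With that in mind, the step from compound 2 to compound 4 is expected to be a 1.5-fold lower number from compound 2 to compound 4 (0.18 log units; within the scatter), a change not clearly beyond the scatter. In this assay compound 4 is therefore estimated at 15000 nM, with a wide range from 3000 nM to 50000 nM.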

Compound 4, half-maximal inhibitory concentration: 15300 nM
Estimate against measurement, compound 4: 1.0-fold (0.01 log units) below; measured number inside the range.
By their numbers in this assay, from the lowest: compounds 4, 2 and 1 (each within the scatter of the next, the first and the last beyond it). At a limit, above all of these: compound 3.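

The first change seen at this position, on a nitrogen on an aromatic ring, replaces 1-methyl-1H-pyrazol-3-yl with 3-cyanophenyl while the chain on the amide stays as it was, and this assay records a 1.5-fold lower number from compound 2 to compound 4 (0.17 log units; within the scatter). The earlier compounds shown here varied only the chain and said nothing about this end of the molecule; this pair shows that a five-membered aromatic ring with 2 hetero atoms and a six-membered aromatic ring of carbon only, bearing a nitrile, cannot be told apart here, so the exchange of ring type produces no change beyond the scatter on this chain. Nothing measured here speaks to why the two groups behave alike.

The compounds shown cannot separate the contribution of the nitrile from that of the ring, which a plain phenyl, or a phenyl carrying an amine or a carboxylic acid in place of the nitrile, would address. They also leave open whether 3-cyanophenyl behaves the same way with the shorter methyl-ended chain or with the isopropyl-ended chain.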